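Ring stereocentre inversion in the acid series

A few compounds are considered here, and "the series" means these few. Any claim that something is new, unique, unknown or untested is made for them only; others in the source may bear on it.

Measured so far:
compound 1, `O=C(O)CC[C@H]1CC[C@@H]2[C@@H](/C=C/[C@@H](O)COc3ccccc3)[C@H](O)C[C@@H]2OC1`: 110 nM
compound 2, `O=C(O)CCCC[C@@H]1CC[C@@H]2[C@@H](/C=C/[C@@H](O)COc3ccccc3)[C@H](O)C[C@@H]2OC1`: 110 nM

Both compounds were run in a functional assay on CHO cells for agonist activity at prostaglandin F2-alpha receptor (Homo sapiens), read by fluorescence and calcium flux; a higher number here means that more compound is needed for the effect, a lower number that less compound is needed. Compound 1 gives 110 nM in this assay. Compound 2 gives 110 nM in this assay, level with compound 1 at the digits reported; the two values lie within the scatter of each other, so no order between them can be read. Among the measured compounds shown here, compound 1 and compound 2 differ in more than one place, so no single-change step between measured compounds is available to calibrate the next move.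

The next compound is compound 3, `O=C(O)CCCC[C@H]1CC[C@@H]2[C@@H](/C=C/[C@@H](O)COc3ccccc3)[C@H](O)C[C@@H]2OC1`. Relative to compound 2, the change is the two compounds have the same atoms and bonds and differ only in configuration as drawn: 1 of 7 stereo elements differ; a stereocentre at a saturated ring carbon is drawn R in compound 2 and S in compound 3. At that ring carbon compound 3 shares its drawn configuration with compound 1, which gives 110 nM in this assay. The step from compound 2 is expected to be none beyond the scatter, no change at the digits printed from compound 2 to compound 3 (within the scatter). Compound 3 is therefore estimated at 110 nM, with a range from 40 nM to 300 nM in this assay.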

Compound 3, half-maximal effective concentration: 43 nM
Beside the measured number, compound 3's estimate is 2.6-fold (0.41 log units) above it; the range from low to high includes it.
By their numbers in this assay, from the lowest: compound 3; then compounds 1 and 2 (each within the scatter of the next).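

In this assay the drawn configuration at the saturated ring carbon matters on its own, with a 2.6-fold lower number from compound 2 to compound 3 (0.41 log units; beyond the scatter), the S form lying on the lower side. With that carbon drawn S, chain length also registers, which the first pair could not show: 2-carboxyethyl in place of carboxy on a saturated chain carbon, two bonds along the chain from a saturated ring carbon, gives a 2.6-fold lower number from compound 1 to compound 3 (0.41 log units; beyond the scatter). The gap between the R and S forms can be assigned to that single stereocentre because nothing else separates them: the fact that compounds 2 and 3 differ only in the configuration as drawn

As far as these compounds go, whether the preference for S carries over to the shorter chain stays open. From the compounds shown here alone, how a methyl ester or a primary amide in place of the carboxylic acid would read with this carbon drawn S also stays open.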